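Replacing the basic amine chain by chloro on a quinoline-type core

The source may hold more compounds than are shown below. What is called first, only, known or untested is meant among the compounds shown, and "the series" means these compounds.

Compound 2: `CN(C)CCCNc1ccnc2cc(OCc3ccc(F)cc3)ccc12` – 490 nM
Compound 1: `Clc1ccnc2cc(OCc3ccccc3)ccc12` – 5170 nM

Of the compounds shown here, two have been measured in a functional assay on BGC-823 cells (Homo sapiens) for cytotoxicity, read by MTT assay, with a stated time of 48 h; on this read-out higher numbers stand for weaker inhibition and lower numbers for stronger inhibition. Compound 2 gives 490 nM, the lowest of the two numbers. Compound 1, which carries chloro in place of the amine side chain and lacks the fluorine on the benzyloxy ring, gives 5170 nM, a gap that lies well beyond the scatter. Among the compounds with values here, no single-point step between the measured compounds is available, so the contribution of each change is not separable.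

The compound now considered is compound 3, `Fc1ccc(COc2ccc3c(Cl)ccnc3c2)cc1`. It differs from compound 2 in one place: chloro in place of (3-(dimethylamino)propyl)amino on an aromatic carbon. With this change compound 3 shares the chloro substituent with compound 1 and keeps the fluorobenzyloxy group of compound 2. Given that compound 1 gives 5170 nM, compound 3 is expected to land close to that figure, with a substantial weakening along a 9.2-fold higher number from compound 2 to compound 3 (0.96 log units; beyond the scatter). The estimate for compound 3 in this assay is 4500 nM, with a range from 1500 nM to 12000 nM.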

Compound 3, half-maximal inhibitory concentration: 2780 nM
For compound 3 the middle estimate is 1.6-fold (0.21 log units) above the measured one; measured number inside the range.
By their numbers in this assay, from the lowest: compound 2; then compounds 3 and 1 (each within the scatter of the next).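

In this assay, the new compound separates the two changes that were mixed between compound 1 and compound 2. With the fluorobenzyloxy group held constant, chloro in place of (3-(dimethylamino)propyl)amino, on the aromatic carbon opposite the ring nitrogen, gives a 5.7-fold higher number from compound 2 to compound 3 (0.75 log units; beyond the scatter), so exchanging the chain alone is enough to produce a clear loss of cytotoxic potency. Fluoro in place of hydrogen on the benzyloxy ring, with chloro present on the shared core, gives a 1.9-fold lower number from compound 1 to compound 3 (0.27 log units; within the scatter), so this change has no effect that can be told from the scatter, and no measurement here explains either step.

The compounds shown do not tell whether the potency of compound 2 depends on the terminal dimethylamino group, the amino nitrogen attached to the core or the length of the chain, which a plain propylamino chain, a shorter or longer dimethylamino chain, or a morpholine at the chain end would begin to separate. They also leave open whether fluoro in place of hydrogen has any effect when the (3-(dimethylamino)propyl)amino chain is present.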